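The source may hold more compounds than are shown below. What is called first, only, known or untested is meant among the compounds shown, and "the series" means these compounds.

Measured so far:

Compound 1 `Cc1cccc(COc2ccc(/C=C/C(/C=C/c3ccccn3)=N/Oc3ncnc4cccc(C)c34)cc2)c1`: 93.4%
Compound 2 `Clc1ccccc1COc1ccccc1/C=C/C(/C=C/c1ccccn1)=N/Oc1ncnc2ccccc12`: 95.7%
Compound 3 `Fc1ccccc1COc1ccccc1/C=C/C(/C=C/c1ccccn1)=N/Oc1ncnc2cc(Cl)ccc12`: 94.2%

All three numbers come from a functional assay on SMMC-7721 cells (Homo sapiens) for inhibition, read by MTT assay, with a stated time of 72 h, tested at 1 uM; on this read-out higher numbers stand for a stronger effect at the one concentration tested and lower numbers for a weaker effect. On the numbers shown, compound 1 has the smallest figure of the three, yet the gap to compound 3 and the gap to compound 2 both lie within the usual scatter of this kind of measurement, so the three compounds cannot be told apart on this read-out. Among the compounds with values here, none of the three differs from another in one place only, so no single step between measured compounds can be read off.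

Compound 4 `Cc1cccc2ncnc(O/N=C(/C=C/c3ccc(OCc4ccccc4Cl)cc3)\C=C\c3ccccn3)c12` has not yet been measured. It differs from compound 1 in one place: 2-chlorophenyl in place of 3-methylphenyl on a saturated chain carbon bound to an oxygen on an aromatic ring. Compound 2 also carries a 2-chlorobenzyl group, and compound 2 in this assay gives 95.7%, a number within the scatter of the value of compound 1, though compound 2 differs from compound 1 elsewhere as well.

Within the data shown here, since every measured compound sits at a high inhibition and the one change is a swap between two groups of the same size, the step from compound 1 to compound 4 is expected to be a number 0.6 percentage points higher from compound 1 to compound 4 (within the scatter), no larger than the scatter and in no clear direction. Compound 4 is therefore estimated at 94% in this assay, with a range from 86% to 98%.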

Compound 4, a percentage reported as inhibition, at one concentration (the size of the read-out at that concentration, not a potency): 77%
For compound 4 the middle estimate is 17 percentage points above the measured one; measured number below the stated range.
By their numbers in this assay, from the lowest: compound 4; then compounds 1, 3 and 2 (each within the scatter of the next).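

In this assay, within the data shown here, putting 2-chlorophenyl in place of 3-methylphenyl on a saturated chain carbon bound to an oxygen on an aromatic ring gives a number 16.4 percentage points lower from compound 1 to compound 4 (beyond the scatter), the first step in this set that can be read at all. This place is therefore not indifferent in this assay: the read-out moves even though the two groups have the same heavy-atom count, the same single six-membered aromatic ring of carbon only, the same counts of hydrogen-bond donors and acceptors, and no net charge, so those counts alone do not predict the outcome here. No measurement shown here explains the drop.

The swap alters two things at once, the kind of substituent on the ring and the number in its name, and this one pair cannot separate them; 3-chlorophenyl or 2-methylphenyl at the same place would be needed to do so. Also open, going by these compounds, is how this place responds to quite different groups, such as an aminomethyl-bearing phenyl or a longer chain, and whether the step would hold at other concentrations, since this read-out shows the size of the effect at one concentration and not a potency.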